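The compounds below may be only part of what the source reports. "The series", "measured", "known", "first", "only" and "open" are said of these compounds alone.

Working notes on the series.

Three compounds of the shared core carry a different aryl group on the double-bonded chain carbon bound to a double-bonded ring carbon. Compound 1 `COc1ccc(/C=C2/SC(N3CCC[C@H]3C(=O)Nc3ccc4ncnc(Nc5cccc(Cl)c5)c4c3)=NC2=O)cc1` gives 19000 nM in a functional assay on HepG2 cells (Homo sapiens) for antiproliferative activity, read by MTT assay; on this read-out higher numbers stand for weaker inhibition and lower numbers for stronger inhibition. Compound 2 `O=C1N=C(N2CCC[C@H]2C(=O)Nc2ccc3ncnc(Nc4cccc(Cl)c4)c3c2)S/C1=C/c1ccc(-c2ccccc2)cc1` gives 15400 nM in this assay, and compound 3 `O=C1N=C(N2CCC[C@H]2C(=O)Nc2ccc3ncnc(Nc4cccc(Cl)c4)c3c2)S/C1=C/c1ccccc1Br` gives 24300 nM. Compound 2 has the lowest number of the three, but compound 1 and compound 3 lie within the scatter of it: the move a 1.2-fold lower number from compound 1 to compound 2 (0.09 log units; within the scatter) and the move a 1.6-fold higher number from compound 2 to compound 3 (0.20 log units; within the scatter) are both within the usual spread, as is a 1.3-fold higher number from compound 1 to compound 3 (0.11 log units; within the scatter).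

Compound 4 `O=C1N=C(N2CCC[C@H]2C(=O)Nc2ccc3ncnc(Nc4cccc(Cl)c4)c3c2)S/C1=C/c1ccccc1F` is not yet measured. It differs from compound 2 by 2-fluorophenyl in place of 4-phenylphenyl on a double-bonded chain carbon bound to a double-bonded ring carbon. For the measured compounds named here, the step that bears most directly on it is the one from compound 2 to compound 3, where 2-bromophenyl also replaced 4-phenylphenyl at the same place and a 1.6-fold higher number from compound 2 to compound 3 (0.20 log units; within the scatter) resulted. The step from compound 1 to compound 3, a 1.3-fold higher number from compound 1 to compound 3 (0.11 log units; within the scatter), likewise stayed within the scatter. On this basis no step beyond the scatter is expected in this assay, with a possible slight drift toward a higher number.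

The estimate for compound 4 is therefore 21000 nM, with a range from 10000 nM to 45000 nM, which means an expected step of a 1.4-fold higher number from compound 2 to compound 4 (0.13 log units; within the scatter).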

Compound 4, half-maximal inhibitory concentration: 18200 nM
Compound 4: the middle estimate sits 1.2-fold (0.06 log units) above what was measured; the measured number falls inside the stated range.
By their numbers in this assay, from the lowest: compounds 2, 4, 1 and 3 (each within the scatter of the next).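

In this assay, the double-bonded chain carbon bound to a double-bonded ring carbon now takes a fourth aryl group with no step beyond the scatter: 2-fluorophenyl gives a 1.2-fold higher number from compound 2 to compound 4 (0.07 log units; within the scatter) against 4-phenylphenyl and a 1.0-fold lower number from compound 1 to compound 4 (0.02 log units; within the scatter) against 4-methoxyphenyl. The series also gains its first exchange of one halogen for another on the aromatic carbon, and a 1.3-fold lower number from compound 3 to compound 4 (0.13 log units; within the scatter) means that fluoro and bromo cannot be told apart on this read-out. The step to compound 4 also removes one of the two aromatic rings of 4-phenylphenyl, with 12 heavy atoms leaving and 7 entering, so a change of this size at this position still leaves the number within the scatter.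

No measurement offered here accounts for this flat response. Going by these compounds, all four groups at this position are substituted phenyl rings, so it remains open whether an amine, a carboxylic acid or a longer chain in their place would produce a step beyond the scatter.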